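Working notes: from compound 2 to compound 3

The source may hold more compounds than are shown below. What is called first, only, known or untested is meant among the compounds shown, and "the series" means these compounds.

- compound 1 `COc1cc(/C=C/C(=O)/C=C/c2cccc3ccccc23)ccc1OCc1cn(CCCOc2cc(=O)oc3ccccc23)nn1`: 10400 nM
- compound 2 `COc1cc(/C=C/C(=O)/C=C/c2cccs2)ccc1OCc1cn(CCOc2cc(=O)oc3ccccc23)nn1`: 9290 nM

In a functional assay on HCT-116 cells (Homo sapiens) for cytotoxicity, read by sulforhodamine B assay, with a stated time of 48 h (on this read-out lower numbers stand for stronger inhibition and higher numbers for weaker inhibition), compound 2 gives 9290 nM, and this lies within the scatter of compound 1 at 10400 nM. For the measured compounds named here, the two structures differ in more than one place, and no single-place step has been measured.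

Compound 3 `COc1cc(/C=C/C(=O)/C=C/c2cc(OC)c(OC)c(OC)c2)ccc1OCc1cn(CCOc2cc(=O)oc3ccccc23)nn1` carries 3,4,5-trimethoxyphenyl in place of thiophen-2-yl on a double-bonded chain carbon bound to a double-bonded chain carbon. The data offer no direct guide to this change, so no step beyond the scatter is expected in this assay, and the uncertainty stays wide in both directions. The expected step of a 1.3-fold lower number from compound 2 to compound 3 (0.12 log units; within the scatter) is small. For compound 3 the estimated value is 7000 nM, with an expected range of 2000 nM to 20000 nM.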

Compound 3, half-maximal inhibitory concentration: 2210 nM
The estimate for compound 3 lay 3.2-fold (0.50 log units) above the measured number; measured number inside the range.
By their numbers in this assay, from the lowest: compound 3; then compounds 2 and 1 (each within the scatter of the next).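

For the compounds shown here, this is the first single-place step. At the double-bonded chain carbon bound to a double-bonded chain carbon, 3,4,5-trimethoxyphenyl in place of thiophen-2-yl gives a 4.2-fold lower number from compound 2 to compound 3 (0.62 log units; beyond the scatter) in this assay and shows that the value responds to the group at this place, which compounds differing in more than one place could not show. The ring and the methoxy groups change together in this one pair, so the step cannot be divided between them, and no measurement on hand accounts for it.

Open, on these data alone, is whether plain phenyl or a pyridine ring at this place would give a step of similar size. Also open, as far as these compounds go, is whether 3,4,5-trimethoxyphenyl gives a comparable step on the core of compound 1.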